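The source may report more compounds than this note shows. Statements on the series, on what has been measured and on what is new or still open speak of the compounds shown alone.

Measured compounds:
compound 1 `C[C@H](Oc1ccc(S(C)(=O)=O)cc1C(=O)N1Cc2ccccc2C1)C(F)(F)F` — 2540 nM
compound 2 `COc1ccc2c(c1)CN(C(=O)c1cc(S(C)(=O)=O)ccc1O[C@@H](C)C(F)(F)F)C2` — 180 nM
compound 3 `C[C@H](Oc1ccc(S(C)(=O)=O)cc1C(=O)N1Cc2ccc(N3CCCC3)cc2C1)C(F)(F)F` — 180 nM

In an assay on CHO cells for inhibition of sodium- and chloride-dependent glycine transporter 1 (Homo sapiens), read by scintillation counting (a higher number here means that more compound is needed for the effect, a lower number that less compound is needed), compound 1 has the highest number of the three. The step of a 14-fold lower number from compound 1 to compound 2 (1.15 log units; beyond the scatter) and the step of a 14-fold lower number from compound 1 to compound 3 (1.15 log units; beyond the scatter) are both large, and the step of no change at the digits printed from compound 2 to compound 3 (within the scatter) shows that a methoxy and a pyrrolidin-1-yl on the core carry the same weight there.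

Compound 4 `Cc1cccc2c1CN(C(=O)c1cc(S(C)(=O)=O)ccc1O[C@@H](C)C(F)(F)F)C2` is now to be measured. Its change from compound 1 is methyl in place of hydrogen on an aromatic carbon, on an aromatic carbon of a six-membered aromatic ring of carbon only, part of a fused or bridged system of two rings, ortho to a fused ring and meta to a fused ring. The two measured steps bear on it only loosely: both replace a hydrogen of the same ring with a heavier group, whereas methyl is a single carbon. Among the compounds with values here, no measured step tests a group this small, so only a moderate gain in this assay is expected, well short of the steps from compound 1 to compounds 2 and 3. For compound 4 the expected step is a 2.5-fold lower number from compound 1 to compound 4 (0.40 log units; beyond the scatter). Compound 4 is therefore estimated at 1000 nM, within 300 nM to 3000 nM.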

Compound 4, half-maximal effective concentration: 3360 nM
Compound 4: middle estimate off by 3.4-fold (0.53 log units), on the low side; the whole stated range lies below it.
By their numbers in this assay, from the lowest: compounds 2 and 3 (each within the scatter of the next); then compounds 1 and 4 (each within the scatter of the next).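

In this assay, methyl on this aromatic carbon, ortho to a fused ring and meta to a fused ring, gives a 1.3-fold higher number from compound 1 to compound 4 (0.12 log units; within the scatter), so this change leaves compound 4 level with compound 1. Substitution on this ring therefore does not bring a gain in every case, unlike the methoxy step a 14-fold lower number from compound 1 to compound 2 (1.15 log units; beyond the scatter) and the pyrrolidin-1-yl step a 14-fold lower number from compound 1 to compound 3 (1.15 log units; beyond the scatter). No measurement is available to explain the absence of a gain with methyl.

The compounds shown do not separate the effect of the group from that of its place on the ring, since methyl is the only group tested at this carbon. Going by these compounds, whether a fluorine atom, a dimethylamino group or a longer alkyl chain here would behave like methyl or give a large step remains open.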